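Replacing the Amine on the Sulfur Chain with a Hydroxyl

The compounds below may be only part of what the source reports. "The series", "measured", "known", "first", "only" and "open" are said of these compounds alone.

In a functional assay on HT cells (Homo sapiens) for antiproliferative activity, read by fluorescence, with a stated time of 72 h (on this read-out lower numbers stand for stronger inhibition of growth and higher numbers for weaker inhibition of growth), compound 1 `CC(C)c1n[nH]c2c(NCc3ccc(-c4ccccn4)cc3)nc(SCCCN(C)C)nc12` gives 105 nM and compound 2 `CC(C)c1n[nH]c2c(NCc3ccc(-c4ccccn4)cc3)nc(SCCCN)nc12` gives 120 nM, so compound 2 stands level with compound 1 within the scatter. Compound 3 `CCC(O)CSc1nc(NCc2ccc(-c3ccccn3)cc2)c2[nH]nc(C(C)C)c2n1` differs from compound 2 by 1-hydroxypropyl in place of 2-aminoethyl on a saturated chain carbon bound to a sulfur. Going by the values given here, one measured step bears on this, a 1.1-fold higher number from compound 1 to compound 2 (0.06 log units; within the scatter), which lies within the scatter. Among the compounds with values here, that step keeps a nitrogen on the chain, and no measured compound lacks one, so it is only a weak guide. The expected change is small and towards weaker inhibition, a 1.3-fold higher number from compound 2 to compound 3 (0.12 log units; within the scatter). Compound 3 is estimated at 160 nM, within a range of 55 nM to 470 nM.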

Compound 3, concentration for 50% growth inhibition: 273 nM
Beside the measured number, compound 3's estimate is 1.7-fold (0.23 log units) below it; measured number inside the range.
By their numbers in this assay, from the lowest: compounds 1 and 2 (each within the scatter of the next); then compound 3.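

In this assay, 1-hydroxypropyl in place of 2-aminoethyl gives a 2.3-fold higher number from compound 2 to compound 3 (0.36 log units; beyond the scatter), and in place of 2-(dimethylamino)ethyl it gives a 2.6-fold higher number from compound 1 to compound 3 (0.41 log units; beyond the scatter). The two chains ending in an amine stood level, so this position does respond once the chain loses its nitrogen, though the loss is modest and compound 3 still gives 273 nM. Nothing available here accounts for the shift. The compounds shown leave open whether the missing amine or the altered chain drives it. A straight 3-hydroxypropyl chain or a carboxylic acid on that chain would help separate the two.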